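The source may report more compounds than this note shows. Statements on the series, on what has been measured and on what is new or still open speak of the compounds shown alone.

Measured compounds in a functional assay on CHO-K1 cells for antagonist activity at transient receptor potential cation channel subfamily V member 1 (Homo sapiens), read by FLIPR; on this read-out higher numbers stand for weaker inhibition and lower numbers for stronger inhibition: compound 1 `CCCCN(C)c1nc(C(F)(F)F)ccc1CNC(=O)C(C)c1ccc(NS(C)(=O)=O)c(F)c1` gives 0.8 nM; compound 2 `CC(C(=O)NCc1ccc(C(F)(F)F)nc1N1CCC(c2ccccc2)CC1)c1ccc(NS(C)(=O)=O)c(F)c1` gives 0.6 nM.

Among the measured compounds shown here, compound 2 gives the lower of the two numbers, but the only measured step, a 1.3-fold lower number from compound 1 to compound 2 (0.12 log units; within the scatter), is within the scatter, so the two compounds cannot be ordered on these data.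

Compound 3 `CC(C(=O)NCc1ccc(C(F)(F)F)nc1N1CCC(Cc2cc(F)cc(F)c2)CC1)c1ccc(NS(C)(=O)=O)c(F)c1` is not yet measured. It differs from compound 2 by 3,5-difluorobenzyl in place of phenyl on a saturated ring carbon. For the measured compounds named here, no measured step touches this position: the step from compound 1 to compound 2 replaced the whole amine substituent on the aromatic carbon rather than a group on the saturated ring carbon, and it was itself within the scatter. The series therefore gives no direction for the change in this assay. Going by the values given here, with both measured compounds sub-nanomolar and the one known step small, compound 3 is expected to stay near compound 2, with a 1.3-fold higher number from compound 2 to compound 3 (0.12 log units; within the scatter) as the estimated step. The estimate for compound 3 in this assay is 0.8 nM, within 0.25 nM to 2.5 nM.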

Compound 3, inhibition constant: 0.4 nM
For compound 3 the middle estimate is 2.0-fold (0.30 log units) above the measured one; measured number inside the range.
By their numbers in this assay, from the lowest: compounds 3, 2 and 1 (each within the scatter of the next).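

In this assay, the saturated ring carbon three ring bonds from the ring nitrogen now has its only direct read, with 3,5-difluorobenzyl in place of phenyl giving a 1.5-fold lower number from compound 2 to compound 3 (0.18 log units; within the scatter). The entering group has 9 heavy atoms against 6, including 2 fluorine atoms, yet compound 3 cannot be told apart from compound 2 on this read-out, so the position tolerates this larger group here. No available data explain this tolerance.

Compound 3 adds the benzyl carbon and the two fluorine atoms together, leaving their separate contributions open; unsubstituted benzyl would help to part them. Also open, as far as these compounds go, is how this assay would respond to an amine or a carboxylic acid at this ring carbon in place of phenyl or 3,5-difluorobenzyl.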